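Replacing 5-methyl-1,3,4-thiadiazol-2-yl with 1-phenyl-1H-tetrazol-5-yl

The compounds below may be only part of what the source reports. "The series", "measured", "known", "first", "only" and "open" are said of these compounds alone.

Measured so far in a functional assay on C6 cells (Rattus norvegicus) for cytotoxicity, read by MTT assay, with a stated time of 24 h, tested at 12 ug/mL; a lower number here means a stronger effect, a higher number a weaker effect of the compound at the concentration tested:
Compound 1 `Cc1nnc(SCC(=O)N/N=c2/scc(-c3ccccc3)n2-c2ccccc2)s1`: 72.5%
Compound 2 `Cc1nnc(SCC(=O)N/N=c2/scc(-c3ccc(F)cc3)n2-c2ccccc2)s1`: 73.7%

Compound 2 stands next to compound 1, the two separated by a number 1.2 percentage points higher from compound 1 to compound 2 (within the scatter), so the pair cannot be told apart in this assay.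

Compound 3 `O=C(CSc1nnnn1-c1ccccc1)N/N=c1/scc(-c2ccc(F)cc2)n1-c1ccccc1` differs from compound 2 by 1-phenyl-1H-tetrazol-5-yl in place of 5-methyl-1,3,4-thiadiazol-2-yl on a sulfur. Going by the values given here, the only measured step, from compound 1 to compound 2, exchanges a hydrogen for a fluoro on a distant aromatic carbon and leaves the group on the sulfur untouched, so it says nothing about how this larger exchange will read in this assay. No step beyond the scatter can be predicted from it in either direction.

For compound 3 the expected step is a number 3.7 percentage points lower from compound 2 to compound 3 (within the scatter), which is an estimate close to no change. Compound 3 is therefore estimated to give 70% in this assay, within a wide range from 45% to 90%.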

Compound 3, a percentage reported as activity, at one concentration (the size of the read-out at that concentration, not a potency): 60%
Compound 3: middle estimate off by 10 percentage points, on the high side; the range from low to high includes it.
By their numbers in this assay, from the lowest: compound 3; then compounds 1 and 2 (each within the scatter of the next).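

Exchanging 5-methyl-1,3,4-thiadiazol-2-yl for 1-phenyl-1H-tetrazol-5-yl on the sulfur gives a number 13.7 percentage points lower from compound 2 to compound 3 (beyond the scatter) in this assay and so shows that the group at this place can move the read-out, which the fluoro exchange on the aromatic carbon did not do. Since a lower number means a stronger effect here, this change goes in the direction of more cytotoxicity at the tested concentration, though the step is modest in size. Nothing measured on these compounds explains the step.

The entering group differs in two ways, a tetrazole ring in place of the thiadiazole ring and an added phenyl ring, and this single exchange cannot separate the two. A 1-methyl-1H-tetrazol-5-yl group on the same sulfur would help to tell them apart.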